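The source may report more compounds than this note shows. Statements on the series, on what has been measured and on what is new or still open speak of the compounds shown alone.

Of the compounds shown here, two have been measured so far. In a functional assay on HCT-116 cells (Homo sapiens) for cytotoxicity, read by MTT assay (a lower number here means a stronger inhibitor, a higher number a weaker inhibitor), compound 1 `O=[N+]([O-])c1ccc2[nH]c(CNc3c([N+](=O)[O-])ccc4ncccc34)nc2c1` gives 256000 nM. In this assay compound 2 `Fc1ccc2nc(NCc3nc4ccccc4[nH]3)sc2c1` gives 238000 nM, and its number and that of compound 1 lie within the usual scatter of each other, so neither can be set apart. Compound 3 `O=[N+]([O-])c1ccc2[nH]c(CNc3nc4ccc(F)cc4s3)nc2c1` has not yet been measured. It differs from compound 2 by a single change: nitro in place of hydrogen on an aromatic carbon. Among the measured compounds shown here, no measured step of this kind is available, so the expected change is a 1.0-fold higher number from compound 2 to compound 3 (0.00 log units; within the scatter), nothing beyond the scatter. Compound 3 is therefore estimated at 240000 nM, with a range from 100000 nM to 550000 nM.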

Compound 3, half-maximal inhibitory concentration: 253000 nM
Estimate against measurement, compound 3: 1.1-fold (0.02 log units) below, within the range that was stated.
By their numbers in this assay, from the lowest: compounds 2, 3 and 1 (each within the scatter of the next).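

Nitro in place of hydrogen on this aromatic carbon gives a 1.1-fold higher number from compound 2 to compound 3 (0.03 log units; within the scatter), so in this assay this change at this position does not set compound 3 apart from compound 2. Among the compounds shown here, this is the only step of its kind, and it rests on a single pair of compounds. Nothing measured here offers an explanation for this result.

On these data alone, whether an amine, a carboxylic acid or a methoxy group on the same aromatic carbon would also stay within the scatter remains open. As far as these compounds go, it is equally open whether any change to the shared core can give a step beyond the scatter in this assay.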